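Inverting the Cyclopropane Stereocentres in a Chroman Acid

The source may hold more compounds than are shown below. What is called first, only, known or untested is meant among the compounds shown, and "the series" means these compounds.

Compound 1 `COc1cc(OC2CCC2)nc(-c2ccc3c(c2)CC[C@H]([C@@H]2C[C@H]2C(=O)O)O3)c1F`: > 10000 nM
Compound 2 `O=C(O)CC[C@H]1CCc2cc(-c3nc(OC4CCC4)ccc3F)ccc2O1`: > 10000 nM
Compound 3 `O=C(O)[C@@H]1C[C@H]1[C@H]1CCc2cc(-c3cc(OC(F)(F)F)ccc3F)ccc2O1`: > 10000 nM

Of the compounds shown here, three have been measured in a functional assay on HEK293 cells for agonist activity at Free fatty acid receptor 1 (Homo sapiens), read by HTRF and inositol phosphate accumulation, with a stated time of 60 min; on this read-out lower numbers stand for an effect already at smaller amounts and higher numbers for an effect only at larger amounts of compound. Compound 1 returns only a limit of the assay, > 10000 nM. Compound 2 likewise sits at a limit, > 10000 nM. Compound 3 also gives only a limit, > 10000 nM, so no number places it relative to the others; all three share (the limit of > 10000 nM in this assay, at which 3 of the 3 values shown sit).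

The account turns to compound 4 `O=C(O)[C@H]1C[C@@H]1[C@H]1CCc2cc(-c3cc(OC(F)(F)F)ccc3F)ccc2O1`, which has not yet been measured in this assay. Compound 4 differs from compound 3 as follows: the two compounds have the same atoms and bonds and differ only in configuration as drawn: 2 of 3 stereo elements differ; a stereocentre at a saturated ring carbon is drawn R in compound 3 and S in compound 4; a stereocentre at a saturated ring carbon is drawn R in compound 3 and S in compound 4. For the measured compounds named here, since only limits are known, no step between measured compounds exists to guide the size of the change. The expectation rests on compound 3 alone, whose limit > 10000 nM offers no measurable baseline; a swap of two stereocentres could move activity in either direction, but with no evidence of activity for compound 3, the step is expected to stay within the limit. Compound 4 is therefore estimated at 10000 nM, with a range from 1000 nM to 30000 nM, corresponding to an expected step of a number no higher from compound 3 to compound 4 (the limit leaves the size open).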

Compound 4, half-maximal effective concentration: > 10000 nM
Compound 4 ended at the assay's limit; the forecaster's own chance of this, stated with the estimate: 70%; the middle value sits exactly at the limit.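

No step can be read from compound 3 to compound 4 in this assay, since both compounds give only a limit of the assay: the limit of > 10000 nM in this assay, at which 4 of the 4 values shown sit. The compounds shown leave open how far the two inverted stereocentres change activity, and whether either configuration gives a measurable value.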